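The source may hold more compounds than are shown below. What is called first, only, known or untested is meant among the compounds shown, and "the series" means these compounds.

Of the compounds shown here, two have been measured in a functional assay on PC-3 cells (Homo sapiens) for antiproliferative activity, read by XTT assay; on this read-out higher numbers stand for weaker inhibition and lower numbers for stronger inhibition. Compound 1 `Cc1ccc2c(=O)c(Cc3coc4cccc(OCC5CCCCC5)c4c3=O)coc2c1` gives 2440 nM in this assay, and compound 2 `COc1ccc2c(=O)c(Cc3coc4cccc(OCC5CCCCC5)c4c3=O)coc2c1` gives 1120 nM. Going by the values given here, the only step between them, a 2.2-fold lower number from compound 1 to compound 2 (0.34 log units; beyond the scatter), is the one measured change at this position, and it amounts to a methoxy in place of methyl on an aromatic carbon. On the two numbers available, compound 2 therefore holds the lowest number, with compound 1 standing a step above it.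

Compound 3 `O=c1c(Cc2coc3cccc(OCC4CCCCC4)c3c2=O)coc2cc(Cl)ccc12` has not yet been measured. It differs from compound 2 by chloro in place of methoxy on an aromatic carbon.

Among the compounds with values here, no measured step involves chloro, so the change into compound 3 can be judged only indirectly. Within the data shown here, the one step that bears on it is the modest one from compound 1 to compound 2, which shows that a swap at this same aromatic carbon moves the number, though only to a modest degree. Since chloro is a new group, the expected step of a 1.6-fold higher number from compound 2 to compound 3 (0.21 log units; within the scatter) is taken as a small rise in the number, close to the scatter and in either direction plausible. Compound 3 is estimated at 1800 nM, with a range from 700 nM to 4500 nM.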

Compound 3, half-maximal inhibitory concentration: > 10000 nM
Compound 3: a limit, no number (the forecaster's own chance of this, stated with the estimate: 3%); middle value at least 5.5-fold (0.74 log units) away from the limit.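

In this assay, compound 3 gives a limit of the assay and not a number: the limit of > 10000 nM in this assay, at which 1 of the 3 values shown sits.

Read with that limit, the swap of chloro for methoxy on this aromatic carbon gives an at least 8.9-fold higher number from compound 2 to compound 3 (0.95 log units; beyond the scatter), and chloro in place of methyl gives an at least 4.0-fold higher number from compound 1 to compound 3 (0.61 log units; beyond the scatter). The earlier pair had shown only that this position responds modestly to a change from methyl to methoxy, with a 2.2-fold lower number from compound 1 to compound 2 (0.34 log units; beyond the scatter); these new steps show that a single replacement here can also cost far more of the antiproliferative effect, so that across the three compounds methoxy gives the lowest number, methyl the next, and chloro the highest, with its true size unknown.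

As far as these compounds go, how far beyond the limit compound 3 lies remains open, and the three compounds cannot separate the arrival of chloro from the departure of an oxygen-bearing group as the source of the loss. From the compounds shown here alone, whether a fluoro, a hydroxyl or an amine on this same aromatic carbon would stay close to compound 2 or fall away like compound 3 also remains open.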